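A Second Fluoro on the Benzyl Group

The compounds below may be only part of what the source reports. "The series", "measured", "known", "first", "only" and "open" are said of these compounds alone.

Measured in a functional assay on Bel7402/5-FU cells (Homo sapiens) for antiproliferative activity, read by MTT assay, with a stated time of 72 h; on this read-out lower numbers stand for stronger inhibition and higher numbers for weaker inhibition:
- Compound 1 `C=C1C(=O)O[C@H]2[C@H]1CC/C(COC(=O)CCC(=O)OCn1cc(F)c(=O)[nH]c1=O)=C\CC[C@@]1(C)O[C@@H]21` gives a limit, not a number (> 20000 nM)
- Compound 2 `C=C1C(=O)O[C@H]2[C@H]1CC/C(Cn1cc(Cn3cc(F)c(=O)n(Cc4ccccc4)c3=O)nn1)=C\CC[C@@]1(C)O[C@@H]21` gives 8840 nM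
- Compound 3 `C=C1C(=O)O[C@H]2[C@H]1CC/C(COC(=O)Cn1cc(F)c(=O)n(Cc3ccc(F)cc3)c1=O)=C\CC[C@@]1(C)O[C@@H]21` gives 1140 nM

Of the two true numbers, the lower belongs to compound 3 (1140 nM), and compound 2 (8840 nM) lies above it by a gap beyond the usual scatter. Compound 4 `C=C1C(=O)O[C@H]2[C@H]1CC/C(COC(=O)Cn1cc(F)c(=O)n(Cc3ccc(F)cc3F)c1=O)=C\CC[C@@]1(C)O[C@@H]21` has not yet been measured. It departs from compound 3 in one place, with 4-fluorobenzyl becoming 2,4-difluorobenzyl (fluoro in place of hydrogen on an aromatic carbon). This is fluoro in place of hydrogen on an aromatic carbon, ortho to a large group and meta to a fluoro group. Among the compounds with values here, no measured pair shows this change, so the expectation starts from compound 3 (1140 nM) and assumes no firm direction. In this assay the step of a 1.1-fold lower number from compound 3 to compound 4 (0.06 log units; within the scatter) is expected to stay within the scatter. The estimated value for compound 4 is 1000 nM (expected range 400 nM to 3000 nM).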

Compound 4, half-maximal inhibitory concentration: 5010 nM
For compound 4 the middle estimate is 5.0-fold (0.70 log units) below the measured one, and the stated range ends below it.
By their numbers in this assay, from the lowest: compound 3; then compounds 4 and 2 (each within the scatter of the next). At a limit, above all of these: compound 1.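

In this assay the change from 4-fluorobenzyl to 2,4-difluorobenzyl gives a 4.4-fold higher number from compound 3 to compound 4 (0.64 log units; beyond the scatter) and so shows that this aromatic carbon, ortho to a large group and meta to a fluoro group, is not a neutral place for a fluoro. Within the data shown here, none of the earlier compounds differed from one another in one place, so this is the first single-atom change that can be read, and it goes towards weaker inhibition. Nothing given here accounts for this loss.

On these data alone, it remains open whether a chloro, a methyl or a methoxy on the same carbon would bring a similar step. Also open, as far as these compounds go, is whether a lone 2-fluorobenzyl group, without the second fluoro, would behave like 4-fluorobenzyl or like 2,4-difluorobenzyl.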